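This account rests on a few compounds, and the source may have more. Where it says the series, first, only, none or still open, it means among the compounds named here.

Measured so far in an assay on microsomes for inhibition of acyl-CoA:cholesterol acyltransferase (Oryctolagus cuniculus); on this read-out higher numbers stand for weaker inhibition and lower numbers for stronger inhibition:
Compound 1 `CC(C)c1cccc(C(C)C)c1NC(=O)NCC1(c2ccc(F)cc2)CCCC1` gives 23 nM.
Compound 2 `CC(C)c1cccc(C(C)C)c1NC(=O)NCC1(c2ccc(OCc3ccccc3)cc2)CCCC1` gives 34 nM.
Compound 3 `CC(C)c1cccc(C(C)C)c1NC(=O)NCC1(c2cccc(N)c2)CCCC1` gives 21 nM.

Compound 3 has the lowest of these three numbers, but its gaps to compound 1 and to compound 2 are within the scatter, so the three compounds stand level. Compound 4 `CC(C)c1cccc(C(C)C)c1NC(=O)NCC1(c2ccc(CO)cc2)CCCC1` differs from compound 3 by 4-(hydroxymethyl)phenyl in place of 3-aminophenyl on a saturated ring carbon. Two earlier steps bear on this: a 1.1-fold lower number from compound 1 to compound 3 (0.04 log units; within the scatter), the replacement of one ring group by another on the saturated ring carbon, and a 1.5-fold higher number from compound 1 to compound 2 (0.17 log units; within the scatter), a change of substituent on an aromatic carbon. Neither moved the number beyond the scatter, so no step beyond the scatter is expected here, a 1.2-fold higher number from compound 3 to compound 4 (0.08 log units; within the scatter). Compound 4 is therefore estimated at 25 nM, between 10 nM and 65 nM.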

Compound 4, half-maximal inhibitory concentration: 26 nM
Compound 4: middle estimate off by 1.0-fold (0.02 log units), on the low side, and the stated range covers the measured number.
By their numbers in this assay, from the lowest: compounds 3, 1, 4 and 2 (each within the scatter of the next).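

In this assay the hydroxymethyl group fits the same picture as the earlier groups: there is a 1.2-fold higher number from compound 3 to compound 4 (0.09 log units; within the scatter) and a 1.1-fold higher number from compound 1 to compound 4 (0.05 log units; within the scatter) and a 1.3-fold lower number from compound 2 to compound 4 (0.12 log units; within the scatter) and all three steps lie within the scatter. Hydroxymethyl, fluoro and benzyloxy on the aromatic carbon thus stand level with each other and with 3-aminophenyl on the saturated ring carbon. No measurement shown offers an explanation for this.

As far as these compounds go, whether a carboxylic acid or a dimethylamino group on the phenyl ring would also stand level remains open. All four compounds share the rest of the core, so the effect of changes there is open too.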